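The source may hold more compounds than are shown below. What is called first, only, known or untested is meant among the compounds shown, and "the series" means these compounds.

Compound 1 `Cc1ccc(S(=O)(=O)c2nc3ccccc3nc2N2CCc3ccccc3C2)cc1` gives 22400 nM in a functional assay on PC-3 cells (Homo sapiens) for cytotoxicity, read by MTT assay, with a stated time of 72 h; a higher number here means a weaker inhibitor, a lower number a stronger inhibitor.
Compound 2 `Cc1ccc(S(=O)(=O)c2nc3ccccc3nc2N2CCCC(O)C2)cc1` gives 5330 nM in this assay.
Compound 3 `O=S(=O)(c1ccccc1)c1nc2ccccc2nc1N1CCC(O)CC1` gives 4980 nM in this assay.

Compound 3 stands at the low end of the three numbers, within the scatter of compound 2 but clearly apart from compound 1. Compound 4 `Cc1ccc(S(=O)(=O)c2nc3ccccc3nc2N2CCC(O)CC2)cc1` differs from compound 3 by methyl in place of hydrogen on an aromatic carbon. Among the compounds with values here, no measured step bears on this change: the only single-point step, a 4.2-fold lower number from compound 1 to compound 2 (0.62 log units; beyond the scatter), exchanges the amine instead. Compound 2 and compound 3 differ in two places at once, and their values lie within the scatter of each other, so nothing indicates that the added methyl shifts the number. Compound 4 is therefore expected to show no step beyond the scatter in this assay, a 1.0-fold higher number from compound 3 to compound 4 (0.00 log units; within the scatter). The estimate for compound 4 is 5000 nM, ranging from 2000 nM to 12500 nM.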

Compound 4, half-maximal inhibitory concentration: 9520 nM
Estimate against measurement, compound 4: 1.9-fold (0.28 log units) below; the range from low to high includes it.
By their numbers in this assay, from the lowest: compounds 3, 2 and 4 (each within the scatter of the next); then compound 1.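

In this assay, the change from phenyl to 4-methylphenyl gives no step beyond the scatter (a 1.9-fold higher number from compound 3 to compound 4 (0.28 log units; within the scatter)), so a methyl at this place leaves the number unresolved from hydrogen. Exchanging 3-hydroxypiperidin-1-yl for 4-hydroxypiperidin-1-yl is likewise within the scatter (a 1.8-fold higher number from compound 2 to compound 4 (0.25 log units; within the scatter)), whereas 4-hydroxypiperidin-1-yl in place of 1,2,3,4-tetrahydroisoquinolin-2-yl gives a modest step (a 2.4-fold lower number from compound 1 to compound 4 (0.37 log units; beyond the scatter)). No evidence is available that accounts for these numbers. From the compounds shown here alone, whether a chlorine or a methoxy group at the same place would shift the number remains open. So does the effect of a morpholine or an open-chain amine in place of the hydroxypiperidine.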